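The source may hold more compounds than are shown below. What is called first, only, known or untested is meant among the compounds shown, and "the series" means these compounds.

Measured compounds in a functional assay on MCF7 cells (Homo sapiens) for cytotoxicity; a higher number here means a weaker inhibitor, a lower number a stronger inhibitor:

compound 1 `C=C/C=C\[C@H](C)[C@H](OC(N)=O)[C@@H](C)[C@H](O)[C@@H](C)C/C(C)=C\[C@H](C)[C@@H](O)[C@@H](C)/C=C\CCc1ccc(Oc2ccccc2)cc1` — 10000 nM
compound 2 `C=C/C=C\[C@H](C)[C@H](OC(N)=O)[C@@H](C)[C@H](O)[C@@H](C)C/C(C)=C\[C@H](C)[C@@H](O)[C@@H](C)/C=C\CCc1cccc(O)c1C` — 1000 nM
compound 3 `C=C/C=C\[C@H](C)[C@H](OC(N)=O)[C@@H](C)[C@H](O)[C@@H](C)C/C(C)=C\[C@H](C)[C@@H](O)[C@@H](C)/C=C\CCc1ccc(C)c(O)c1` — 4000 nM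

Compound 2 gives the lowest number of the three in this assay. For the measured compounds named here, its nearest neighbour is compound 3, reached by a 4.0-fold higher number from compound 2 to compound 3 (0.60 log units; beyond the scatter); compound 1 shows a higher number than either, but no single-point step joins compound 1 to compound 2, so only the two values themselves can be compared.

The unmeasured compound 4 `C=C/C=C\[C@H](C)[C@H](OC(N)=O)[C@@H](C)[C@H](O)[C@@H](C)C/C(C)=C\[C@H](C)[C@@H](O)[C@@H](C)/C=C\CCc1cccc(OC)c1` differs from compound 2 by 3-methoxyphenyl in place of 3-hydroxy-2-methylphenyl on a saturated chain carbon, two bonds along the chain from a double-bonded chain carbon. Going by the values given here, the one measured step at this position, a 4.0-fold higher number from compound 2 to compound 3 (0.60 log units; beyond the scatter), kept both the hydroxy and the methyl of the ring and still raised the number beyond the scatter. Compound 4 keeps neither as such; the ring carries 3-methoxyphenyl. Compound 1, whose ring likewise lacks a hydroxy, gives 10000 nM. A step upward in this assay at least as large as the measured one is therefore expected, written as a 4.0-fold higher number from compound 2 to compound 4 (0.60 log units; beyond the scatter). For compound 4 the expected value is 4000 nM, with a range from 1500 nM to 12000 nM.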

Compound 4, half-maximal inhibitory concentration: 500 nM
For compound 4 the middle estimate is 8.0-fold (0.90 log units) above the measured one, outside the stated range (below it).
By their numbers in this assay, from the lowest: compounds 4 and 2 (each within the scatter of the next); then compound 3; then compound 1.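

In this assay, moving to 3-methoxyphenyl on this saturated chain carbon gives a 2.0-fold lower number from compound 2 to compound 4 (0.30 log units; within the scatter) and so shows that the ring hydroxy and the ring methyl of 3-hydroxy-2-methylphenyl can both go without a change beyond the scatter. Set against 3-hydroxy-4-methylphenyl, the same ring gives an 8.0-fold lower number from compound 3 to compound 4 (0.90 log units; beyond the scatter) and so shows that a ring hydroxy does not by itself set the number here: one hydroxy-bearing ring stays within the scatter of 3-methoxyphenyl and the other lies beyond it. Nothing available accounts for either step.

Still open, from the compounds shown here alone, is how far the oxygen substituent matters at all, as a plain phenyl or 3-hydroxyphenyl would test. Also open, going by these compounds, is how a ring bearing an amine or a carboxylic acid would read in this assay series.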